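Notes on the step from compound 3 to compound 4

A few compounds are considered here, and "the series" means these few. Any claim that something is new, unique, unknown or untested is made for them only; others in the source may bear on it.

In a functional assay on U-373MG ATCC cells (Homo sapiens) for inhibition, read by MTT assay, with a stated time of 72 h (a higher number here means a weaker inhibitor, a lower number a stronger inhibitor), compound 1 `CC1(C)CC(NC(=O)Nc2ccccc2)c2cc(Cl)ccc2O1` gives 68000 nM and compound 2 `CC1(C)CC(NC(=O)Nc2ccccc2Cl)c2cc(Cl)ccc2O1` gives 17000 nM. Compound 3 `CCNC(=S)NC1CC(C)(C)Oc2ccc(Cl)cc21` gives 96000 nM, which is within the scatter of compound 1 and differs from compound 2 by more than the scatter. Compound 3 therefore sits with compound 1 at the weak end of these three values.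

The next structure is compound 4 `CC(C)NC(=O)NC1CC(C)(C)Oc2ccc(Cl)cc21`. The change is a group of 6 heavy atoms (4 carbon, 1 nitrogen, 1 oxygen; no ring) in place of a group of 5 heavy atoms (3 carbon, 1 nitrogen, 1 sulfur; no ring), on an amine nitrogen, with isopropylcarbamoyl entering on an amine nitrogen. Within the data shown here, no measured step covers this kind of change. The only one available, a 4.0-fold lower number from compound 1 to compound 2 (0.60 log units; beyond the scatter), is a chloro in place of hydrogen on an aromatic carbon, so it serves only as a rough gauge of size in this series. With no direct evidence for a shift, no step beyond the scatter is expected in this assay, and either direction remains possible. The expected step is a 1.1-fold lower number from compound 3 to compound 4 (0.03 log units; within the scatter). For compound 4 the estimated value is 90000 nM, with an expected range of 35000 nM to 230000 nM.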

Compound 4, half-maximal inhibitory concentration: 62000 nM
For compound 4 the middle estimate is 1.5-fold (0.16 log units) above the measured one; low and high end bracket the measured number.
By their numbers in this assay, from the lowest: compound 2; then compounds 4, 1 and 3 (each within the scatter of the next).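

In this assay, isopropylcarbamoyl in place of the sulfur-bearing group on the amine nitrogen gives a 1.5-fold lower number from compound 3 to compound 4 (0.19 log units; within the scatter), so this exchange does not separate the two compounds. On the amide-type nitrogen, isopropyl in place of phenyl gives a 1.1-fold lower number from compound 1 to compound 4 (0.04 log units; within the scatter), so the phenyl ring is not needed to hold a value of this size, whereas isopropyl in place of 2-chlorophenyl gives a 3.6-fold higher number from compound 2 to compound 4 (0.56 log units; beyond the scatter). Among these compounds, compound 2 thus remains the only compound set apart from the other three, and no supporting data bear on the reason.

Open, on these data alone, is whether sulfur or oxygen matters with the nitrogen substituent held fixed, as compound 3 and compound 4 differ in both. Also open, as far as these compounds go, is whether a longer chain, an amine or a carboxylic acid on that nitrogen would come close to compound 2, with 17000 nM.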